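Lipophilicity notes: iodo to bromo on the core

The source may report more compounds than this note shows. Statements on the series, on what has been measured and on what is new or still open speak of the compounds shown alone.

Of the compounds shown here, two have been measured in a physicochemical assay for lipophilicity; on this read-out lower numbers stand for lower lipophilicity and higher numbers for higher lipophilicity. Compound 1 `CS(=O)(=O)c1ccc(-c2cnc(I)n2-c2ccc(F)c(F)c2)cc1` gives 3.88 and stands lowest of the two numbers; compound 2 `CS(=O)(=O)c1ccc(-c2c(Cl)nc(Cl)n2-c2ccc(F)c(F)c2)cc1` gives 4.44, a higher value beyond the usual scatter. Compound 3 `CS(=O)(=O)c1ccc(-c2cnc(Br)n2-c2ccc(F)c(F)c2)cc1` remains to be measured. It differs from compound 1 by bromo in place of iodo on an aromatic carbon. Within the data shown here, no measured pair shows this change directly, so only the value of compound 1 serves as anchor. A small decrease, near the edge of the scatter, is expected for the step of a number 0.23 log units lower from compound 1 to compound 3 (within the scatter) in this assay. Compound 3 is estimated at 3.65, within a range from 3.35 to 3.95.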

Compound 3, partition coefficient: 3.7
Beside the measured number, compound 3's estimate is 0.05 log units below it; the range from low to high includes it.
By their numbers in this assay, from the lowest: compounds 3 and 1 (each within the scatter of the next); then compound 2.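

Among these compounds, this is the first direct reading of a single change at this position, on an aromatic carbon between two ring nitrogen atoms. In this assay, bromo in place of iodo gives a number 0.18 log units lower from compound 1 to compound 3 (within the scatter), so this read-out does not separate the two halogens here. No measurement available explains this result.

Going by these compounds, whether an amine or a carboxylic acid at this position would give a step beyond the scatter remains open. On these data alone, compound 2 differs from compound 1 in more than one place, so the effect of a lone chloro here also remains open.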